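Dropping Two Chlorines from an Arylsulfonamide Thromboxane Antagonist

This account rests on a few compounds, and the source may have more. Where it says the series, first, only, none or still open, it means among the compounds named here.

Within the data shown here, compound 2 `O=C(O)COCCCCC1=CCC[C@@H]1NS(=O)(=O)c1ccc(Cl)c(Cl)c1` is tested in a functional assay on a cell-free system (plasma) for inhibition of thromboxane A2 receptor (Homo sapiens), read by turbidimetry (on this read-out lower numbers stand for stronger inhibition and higher numbers for weaker inhibition), where compound 2 gives 1900 nM; this is the only number reported for it, and one further record carries no single value. Alongside it stands compound 1 `O=C(O)CC/C=C\C[C@@H]1[C@@H](CNS(=O)(=O)c2ccc(F)cc2)CC[C@H]1F`, for which the several entries of compound 1 in this assay, 1900 nM; 1900 nM; 650 nM (3 entries) shows how repeated runs spread, compound 1 giving 1900 nM; 1900 nM; 650 nM (3 entries) in this assay.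

Compound 3 `O=C(O)COCCCCC1=CCC[C@@H]1NS(=O)(=O)c1ccccc1` has not yet been measured in this assay. Compared with compound 2, it shows (phenyl in place of 3,4-dichlorophenyl on a sulfonyl sulfur). Among the measured compounds shown here, no measured pair in this set isolates this change, so the size of the step in this assay rests on expectation alone. Compound 3 is expected to be somewhat weaker than compound 2, with the expected step of a 3.2-fold higher number from compound 2 to compound 3 (0.50 log units; beyond the scatter) reaching beyond the usual scatter. Compound 3 is accordingly estimated at 6000 nM, within a range from 1500 nM to 25000 nM.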

Compound 3, half-maximal inhibitory concentration: 2000 nM
Beside the measured number, compound 3's estimate is 3.0-fold (0.48 log units) above it; low and high end bracket the measured number.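

In this assay, taking away the two chlorines leaves the number in place: a 1.1-fold higher number from compound 2 to compound 3 (0.02 log units; within the scatter). Among these compounds, this is the first measured pair that isolates a change on a sulfonyl sulfur, and it shows that phenyl can stand in place of 3,4-dichlorophenyl with no difference that can be read. A step of this size has to be judged against how far repeated runs of a single compound spread: the several entries of compound 1 in this assay, 1900 nM; 1900 nM; 650 nM (3 entries).

Going by these compounds, whether a 4-methoxyphenyl, a naphthyl or a pyridyl group on the same sulfonyl sulfur would shift the number remains open. Also open, on these data alone, is whether phenyl in place of the aryl group would read the same way on the core of compound 1.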